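Working notes: phenyl to 4-bromophenyl

This account rests on a few compounds, and the source may have more. Where it says the series, first, only, none or still open, it means among the compounds named here.

In a functional assay on HepG2 cells (Homo sapiens) for antiproliferative activity, read by MTT assay (on this read-out higher numbers stand for weaker inhibition and lower numbers for stronger inhibition), compound 1 `CCNC(=O)c1oc2nc(-c3ccccc3)cc(C(F)(F)F)c2c1N` gives 42800 nM, compound 2 `Nc1c(C(=O)N/N=C/c2ccccc2)oc2nc(-c3ccccc3)cc(C(F)(F)F)c12` gives 13100 nM and compound 3 `Nc1c(C(=O)N/N=C/c2ccccc2)oc2nc(-c3cccs3)cc(C(F)(F)F)c12` gives 9900 nM. Compound 2 thus stands clearly lower than compound 1 and level with compound 3. Compound 4 `Nc1c(C(=O)N/N=C/c2ccc(Br)cc2)oc2nc(-c3ccccc3)cc(C(F)(F)F)c12` differs from compound 2 by bromo in place of hydrogen on an aromatic carbon, para to a large group. Going by the values given here, no measured step tests this change directly. The amide-nitrogen change, a 3.3-fold lower number from compound 1 to compound 2 (0.51 log units; beyond the scatter), was modest and much larger in atoms. The aryl swap, a 1.3-fold lower number from compound 2 to compound 3 (0.12 log units; within the scatter), stayed within the scatter. The expected 1.3-fold lower number from compound 2 to compound 4 (0.12 log units; within the scatter) is therefore no step beyond the scatter. Compound 4 is expected at 10000 nM, within an estimated range of 4000 nM to 25000 nM.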

Compound 4, half-maximal inhibitory concentration: 19900 nM
Beside the measured number, compound 4's estimate is 2.0-fold (0.30 log units) below it, and the stated range covers the measured number.
By their numbers in this assay, from the lowest: compounds 3, 2 and 4 (each within the scatter of the next); then compound 1.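

Moving from phenyl to 4-bromophenyl gives in this assay a 1.5-fold higher number from compound 2 to compound 4 (0.18 log units; within the scatter), so a bromo para to a large group leaves the number level with the unsubstituted ring. The larger group on the amide-type nitrogen keeps its separation with the bromo present, with a 2.2-fold lower number from compound 1 to compound 4 (0.33 log units; beyond the scatter), though this step is modest. Nothing at hand accounts for either step.

Going by these compounds, whether a methoxy, an amine or a carboxylic acid at this same place would also stay level remains open. So does the effect of bromo alongside the thiophen-2-yl of compound 3.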